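A Methyl Next to the Ring Nitrogen: Compound 4 Expected

The source may hold more compounds than are shown below. What is called first, only, known or untested is meant among the compounds shown, and "the series" means these compounds.

Of the compounds shown here, three of a shared core have been measured in a functional assay on HeLa cells (Homo sapiens) for cytotoxicity, read by MTT assay, with a stated time of 72 h, tested at 1 uM; on this read-out lower numbers stand for less inhibition of growth and higher numbers for more inhibition of growth at the one concentration tested. Compound 1 `N/C(=N\NC(=S)N1CCOCC1)c1ccccn1` gives 12.7% in this assay. Compound 3 `N/C(=N\NC(=S)N1CCCCC1)c1ccccn1` gives 15.5% in this assay, and compound 2 `Cc1cccc(/C(N)=N/NC(=S)N2CCSCC2)n1` gives 46.5% in this assay. Within the data shown here, compound 3 stands second highest of these three numbers; its nearest neighbour is compound 1, and the one step that links them, a number 2.8 percentage points higher from compound 1 to compound 3 (within the scatter), lies within the scatter, while compound 2 lies well beyond it.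

The next compound, compound 4 `Cc1cccc(/C(N)=N/NC(=S)N2CCCCC2)n1`, differs from compound 3 in one place: methyl in place of hydrogen on an aromatic carbon. Among the measured compounds shown here, no measured pair differs only in this way. Compound 2 carries the same methyl together with a different ring on the thiocarbonyl carbon, so its higher number cannot be separated into the two changes it combines. For the measured compounds named here, the only step that has been measured, a number 2.8 percentage points higher from compound 1 to compound 3 (within the scatter), concerns the ring on the thiocarbonyl carbon and not the methyl, and it was within the scatter.

For compound 4 the step from compound 3 is therefore expected to be a number 10.5 percentage points higher from compound 3 to compound 4 (beyond the scatter), a direction taken from compound 2 with the caution that it rests on a single comparison. Compound 4 is estimated at 26% in this assay, with a range from 8% to 50%.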

Compound 4, percent growth inhibition at one concentration: 27%
Beside the measured number, compound 4's estimate is 1 percentage points below it; measured number inside the range.
By their numbers in this assay, from the lowest: compounds 1 and 3 (each within the scatter of the next); then compound 4; then compound 2.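

Among these compounds, the methyl on the aromatic carbon next to the ring nitrogen now has a step of its own in this assay: the change from hydrogen to methyl gives a number 11.5 percentage points higher from compound 3 to compound 4 (beyond the scatter) with the piperidin-1-yl group held constant, whereas the only earlier step, a number 2.8 percentage points higher from compound 1 to compound 3 (within the scatter), concerned the ring on the thiocarbonyl carbon. With the methyl held constant, that ring also matters, since piperidin-1-yl in place of thiomorpholin-4-yl gives a number 19.5 percentage points lower from compound 2 to compound 4 (beyond the scatter) and this step lies beyond the scatter. The high number of compound 2 therefore no longer stands as one combined change, as compound 4 divides the route from compound 3 to compound 2 into two single changes, each beyond the scatter. No measurement on hand offers an explanation for either step.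

The compounds shown leave open whether the methyl gives a step of similar size when morpholin-4-yl sits on the thiocarbonyl carbon. They also leave open whether an ethyl or a methoxy group on the same aromatic carbon would move the number in the same direction as the methyl.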